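This account rests on a few compounds, and the source may have more. Where it says the series, first, only, none or still open, it means among the compounds named here.

Measured so far in an ADME assay (liver) for metabolic stability, with Liver microsome (Rattus norvegicus) as the target, using microsomes and NADPH, with a stated time of 30 min, at 37 degrees C, tested at 1 uM; on this read-out higher numbers stand for fast clearance and lower numbers for slow clearance:
Compound 1 `CC(O)(c1ccc(-c2ccc(S(=O)(=O)c3ccc(N)nc3)cc2)cc1)C(F)(F)F` gives < 14 mL.min-1.g-1 as a limit
Compound 2 `COc1cc(C(O)(C(F)(F)F)C(F)(F)F)cnc1-c1ccc(S(=O)(=O)c2ccc(N)nc2)cc1` gives < 14 mL.min-1.g-1 as a limit
Compound 3 `N#Cc1cc(C(O)(C(F)(F)F)C(F)(F)F)cnc1-c1ccc(S(=O)(=O)c2ccc(N)nc2)cc1` gives 27 mL.min-1.g-1 as a true number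

Compound 3 is the only one of these with an exact figure. Compound 1 and compound 2 stop at the limit of < 14 mL.min-1.g-1 in this assay, at which 2 of the 3 values shown sit, and give no exact figure. Compound 4 `CC(C)(O)C#Cc1cc(C(O)(C(F)(F)F)C(F)(F)F)cnc1-c1ccc(S(=O)(=O)c2ccc(N)nc2)cc1` carries 3-hydroxy-3-methylbut-1-yn-1-yl in place of cyano on an aromatic carbon and otherwise matches compound 3. Among the compounds with values here, one measured step touches this carbon, an at least 1.9-fold higher number from compound 2 to compound 3 (0.28 log units; that floor lies within the scatter) for cyano in place of methoxy. That step is only a floor and says little about the new group. No step beyond the scatter is therefore expected, and the estimated change is a 1.4-fold lower number from compound 3 to compound 4 (0.13 log units; within the scatter) in this assay and no more. For compound 4 the expected value is 20 mL.min-1.g-1 with an estimated range from 9 mL.min-1.g-1 to 45 mL.min-1.g-1 and the assay may again report only a limit.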

Compound 4, intrinsic clearance in microsomes: < 14 mL.min-1.g-1
Compound 4 ended at the assay's limit; the forecaster's own chance of this, stated with the estimate: 35%; at least 1.4-fold (0.15 log units) between middle value and limit.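

In this assay, putting 3-hydroxy-3-methylbut-1-yn-1-yl in place of cyano gives an at least 1.9-fold lower number from compound 3 to compound 4 (0.28 log units; that floor lies within the scatter). This carbon therefore holds a larger chain with a hydrogen-bond donor without any rise in the number, although that floor alone does not establish a real drop. The step between methoxy and the new group cannot be read, with both compounds ending at a limit: the limit of < 14 mL.min-1.g-1 in this assay, at which 3 of the 4 values shown sit.

On these data alone, whether an amine or a carboxylic acid on this carbon would also keep the number low remains open. So does the true order of compound 2 and compound 4.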